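Chain shortening on the shared core: compound 2 to compound 3

This account rests on a few compounds, and the source may have more. Where it says the series, first, only, none or still open, it means among the compounds named here.

compound 1 `C=CCc1c(OC)nc2nc(C(=O)c3ccccc3)cn2c1C` — 5 mg/kg
compound 2 `CCCCc1cc(OC)nc2nc(C(=O)c3ccccc3)cn12` — 10 mg/kg

In a functional assay on the whole organism with Rattus norvegicus as the target (on this read-out higher numbers stand for an effect only at larger amounts of compound and lower numbers for an effect already at smaller amounts), compound 2 gives 10 mg/kg, the highest of the two numbers; compound 1 gives 5 mg/kg, which lies within the scatter of it, so the two say nothing about order. Compound 3 `COc1cc(C)n2cc(C(=O)c3ccccc3)nc2n1` differs from compound 2 by hydrogen in place of propyl on a saturated chain carbon bound to an aromatic carbon. Among the measured compounds shown here, no measured pair reads on this change, so the expectation rests on the change alone. Compound 3 is expected at 20 mg/kg, between 8 mg/kg and 60 mg/kg. The step of a 2.0-fold higher number from compound 2 to compound 3 (0.30 log units; within the scatter) is expected to run toward an effect only at larger amounts, somewhat beyond the scatter.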

Compound 3, minimum effective dose: 5 mg/kg
Beside the measured number, compound 3's estimate is 4.0-fold (0.60 log units) above it, and the stated range ends above it.
By their numbers in this assay, from the lowest: compounds 1, 3 and 2 (each within the scatter of the next).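

In this assay, hydrogen in place of propyl on a saturated chain carbon bound to an aromatic carbon gives a 2.0-fold lower number from compound 2 to compound 3 (0.30 log units; within the scatter) and so does not separate butyl from methyl at this place. Hydrogen in place of allyl on an aromatic carbon gives no change at the digits printed from compound 1 to compound 3 (within the scatter) and likewise shows no readable contribution from the allyl group. No supporting data bear on either result.

Going by these compounds, whether a chain longer than butyl, an amine or a carboxylic acid at these places would move the number beyond the scatter remains open.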